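The source may hold more compounds than are shown below. What is called first, only, known or untested is meant among the compounds shown, and "the series" means these compounds.

Compound 1 `c1ccc(-c2ccnc(Nc3cccc(OCCn4ccnc4)c3)n2)nc1`, compound 2 `CN(C)c1cccc(Nc2nccc(-c3cccs3)n2)c1` and compound 3 `NS(=O)(=O)c1cccc(Nc2nccc(-c3ccccn3)n2)c1` share one core and differ in the group carried on an aromatic carbon of a six-membered aromatic ring, and in one case also in the ring attached to the core. In a functional assay for inhibition, with Homo sapiens as the target (on this read-out higher numbers stand for weaker inhibition and lower numbers for stronger inhibition), compound 1 gives 400 nM, compound 2 gives 2400 nM and compound 3 gives 500 nM. Compound 3 therefore stands second highest of the three numbers, close to compound 1 and well apart from compound 2. Among the measured compounds shown here, the one step measured between neighbouring structures, a 1.3-fold higher number from compound 1 to compound 3 (0.10 log units; within the scatter), shows sulfamoyl and the 2-(1H-imidazol-1-yl)ethoxy group giving much the same result.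

Compound 4 `CN(C)c1cccc(Nc2nccc(-c3ccccn3)n2)c1` differs from compound 3 in a single place: dimethylamino in place of sulfamoyl on an aromatic carbon. For the measured compounds named here, no measured step exchanges these two groups directly. Going by the values given here, the only bearing comes from compound 2, which also carries dimethylamino but a different ring on the core, and whose number in this assay is clearly higher than that of compound 3. On that evidence a weakening is expected for compound 4, a 2.6-fold higher number from compound 3 to compound 4 (0.41 log units; beyond the scatter), with considerable uncertainty. Compound 4 is estimated at 1300 nM, within a range from 450 nM to 4000 nM.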

Compound 4, half-maximal inhibitory concentration: 400 nM
Compound 4: middle estimate off by 3.3-fold (0.51 log units), on the high side; measured number below the stated range.
By their numbers in this assay, from the lowest: compounds 1, 4 and 3 (each within the scatter of the next); then compound 2.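

In this assay, dimethylamino on the aromatic carbon turns out to be interchangeable with sulfamoyl (a 1.3-fold lower number from compound 3 to compound 4 (0.10 log units; within the scatter)) and with 2-(1H-imidazol-1-yl)ethoxy (no change at the digits printed from compound 1 to compound 4 (within the scatter)), so with pyridin-2-yl on the core these three quite different groups cannot be told apart at this place, although sulfamoyl has a hydrogen-bond donor and dimethylamino has none. Among the compounds shown here, the high number of compound 2 therefore does not go with dimethylamino: with that group held constant, pyridin-2-yl in place of thiophen-2-yl on an aromatic carbon gives a step beyond the scatter (a 6.0-fold lower number from compound 2 to compound 4 (0.78 log units; beyond the scatter)), which makes the ring on the core the one change here that separates the compounds. Nothing available explains either the tolerance at this place or the difference between the two rings.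

From the compounds shown here alone, whether the tolerance extends to a carboxylic acid, a primary amine or a longer alkoxy chain on this carbon remains open. So does whether the step between the two rings holds with sulfamoyl or 2-(1H-imidazol-1-yl)ethoxy in place of dimethylamino, and how a phenyl or a pyridin-3-yl ring on the core would compare.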